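A few compounds are considered here, and "the series" means these few. Any claim that something is new, unique, unknown or untested is made for them only; others in the source may bear on it.

Measured compounds in an assay on HeLa cells for inhibition of sphingosine-1-phosphate transporter SPNS2 (Mus musculus), read by LC-MS, tested at 2 uM; a lower number here means less inhibition, a higher number more inhibition at the concentration tested (going by the name of the read-out):
compound 1 `CCCCCCCCCCc1ccc(-c2noc(CC3CNC3)n2)cc1` gives 63%
compound 2 `CCCCCCCCCCc1ccc(-c2noc(CC[C@@H](N)C(=O)O)n2)cc1` gives 5%

For the measured compounds named here, compound 2 stands lowest of the two numbers in this assay; its nearest neighbour is compound 1, and the only measured step, a number 58 percentage points lower from compound 1 to compound 2 (beyond the scatter), was large and beyond the scatter. Compound 3 `CCCCCCCCCCc1ccc(-c2noc([C@H](CCCCN)NC(C)=O)n2)cc1` is not yet measured in this assay. It differs from compound 2 by 1-acetamido-5-aminopentyl in place of 3-amino-3-carboxypropyl on an aromatic carbon. Going by the values given here, the single step that bears on this position is a number 58 percentage points lower from compound 1 to compound 2 (beyond the scatter), where the 2-amino-2-carboxyethyl group took the inhibition down from the level of compound 1 to that of compound 2. Compound 3 loses the carboxy-bearing group again and carries an amino group on its chain, which places it structurally between the two measured compounds, so a step upward is expected in this assay, though its size cannot be fixed from one prior step. For compound 3 a value of 35% is estimated, with a range from 5% to 65%, meaning an expected step of a number 30 percentage points higher from compound 2 to compound 3 (beyond the scatter).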

Compound 3, a percentage reported as inhibition, at one concentration (the size of the read-out at that concentration, not a potency): 40%
Beside the measured number, compound 3's estimate is 5 percentage points below it; measured number inside the range.
By their numbers in this assay, from the lowest: compound 2; then compound 3; then compound 1.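

In this assay the step of a number 35 percentage points higher from compound 2 to compound 3 (beyond the scatter) shows that an open-chain substituent without a ring can carry substantial inhibition at this position, so the low number of compound 2 does not extend to every open-chain group bearing an amine. The step of a number 23 percentage points lower from compound 1 to compound 3 (beyond the scatter) shows that the 1-acetamido-5-aminopentyl group still does not reach the level seen with the (azetidin-3-yl)methyl group. No evidence is available to explain either step.

As far as these compounds go, the change from compound 2 to compound 3 alters chain length, the acetamido group and the carboxy group together, so the part responsible for the rise remains open. A plain 5-aminopentyl group, or a carboxylic acid placed on the longer chain, would separate these contributions, and the role of the stereocentre also remains unresolved.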